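A few compounds are considered here, and "the series" means these few. Any claim that something is new, unique, unknown or untested is made for them only; others in the source may bear on it.

For the measured compounds named here, compound 2 `Cc1ccc(Cn2cc(CSC(=S)N3CCN(C(=O)OC(C)(C)C)CC3)nn2)cc1` is the only compound in this set with a number in a functional assay on ECa-109 cells (Homo sapiens) for inhibition, read by MTT assay, with a stated time of 72 h; a lower number here means a stronger inhibitor, a higher number a weaker inhibitor: compound 2 gives 47900 nM. Compound 1 `CC(C)(C)OC(=O)N1CCN(C(=S)SCc2cn(-c3ccccc3F)nn2)CC1` gives only a limit in this assay, > 128000 nM. Going by the values given here, the single measured step, an at least 2.6-fold lower number from compound 1 to compound 2 (0.42 log units; beyond the scatter), therefore starts from the limit of > 128000 nM in this assay, at which 1 of the 2 values shown sits, and concerns the group on the aromatic nitrogen. Compound 3 `CC(C)(C)OC(=O)N1CCN(C(=S)SCc2cn(Cc3ccc(Cl)cc3)nn2)CC1` differs from compound 2 by chloro in place of methyl on an aromatic carbon. Among the compounds with values here, no measured step touches this position, so no change beyond the scatter is anticipated. Compound 3 is expected at 42000 nM (range 15000 nM to 120000 nM), an estimated step of a 1.1-fold lower number from compound 2 to compound 3 (0.06 log units; within the scatter).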

Compound 3, half-maximal inhibitory concentration: > 128000 nM
Compound 3 gave a limit, no number (the forecaster's own chance of this, stated with the estimate: 15%); at least 3.0-fold (0.48 log units) between middle value and limit.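

In this assay, the earlier step concerned only the group on the aromatic nitrogen; this one shows that a single-atom change on the aromatic carbon, para to a large group, also matters: chloro in place of methyl gives an at least 2.6-fold higher number from compound 2 to compound 3 (0.42 log units; beyond the scatter). As far as these compounds go, compound 3 gives only a limit, so the true size of this step is unknown, and the step from compound 1 to compound 3 cannot be read. Only the methyl compound gives a number so far, with the others at a shared limit: the limit of > 128000 nM in this assay, at which 2 of the 3 values shown sit.

From the compounds shown here alone, whether methoxy, an amine or a longer chain in place of methyl would give a number in this assay remains open.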